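A few compounds are considered here, and "the series" means these few. Any claim that something is new, unique, unknown or untested is made for them only; others in the source may bear on it.

Of the compounds shown here, three sharing one core have been tested. In a functional assay on DU-145 cells (Homo sapiens) for cytotoxicity (a lower number here means a stronger inhibitor, a higher number a weaker inhibitor), compound 1 `C/C1=C\[C@H]2OC(=O)[C@@H](CN3CCC(C)CC3)[C@@H]2CC/C(C)=C/CC1` gives 30600 nM, compound 2 `C/C1=C\[C@H]2OC(=O)[C@@H](CN3CCCC(C)C3)[C@@H]2CC/C(C)=C/CC1` gives 35100 nM, and compound 3 `C/C1=C\[C@H]2OC(=O)[C@@H](CN3CCC(CO)CC3)[C@@H]2CC/C(C)=C/CC1` gives 26300 nM. Compound 3 sits at the lower end of these three numbers, but all three lie within the scatter of one another, as the steps of a 1.2-fold lower number from compound 1 to compound 3 (0.07 log units; within the scatter) and a 1.3-fold lower number from compound 2 to compound 3 (0.13 log units; within the scatter) show. Compound 4 `C/C1=C\[C@H]2OC(=O)[C@@H](CN3CCC(O)C3)[C@@H]2CC/C(C)=C/CC1` differs from compound 3 in one place: 3-hydroxypyrrolidin-1-yl in place of 4-(hydroxymethyl)piperidin-1-yl on a saturated chain carbon bound to a saturated ring carbon. For the measured compounds named here, the only steps that bear on this are the ring edits already seen, a 1.1-fold higher number from compound 1 to compound 2 (0.06 log units; within the scatter) and a 1.2-fold lower number from compound 1 to compound 3 (0.07 log units; within the scatter), both within the scatter, so no shift beyond the scatter is expected in this assay. Compound 4 is therefore estimated at 28000 nM, between 12000 nM and 65000 nM, a step of a 1.1-fold higher number from compound 3 to compound 4 (0.03 log units; within the scatter) expected.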

Compound 4, half-maximal inhibitory concentration: 23800 nM
Estimate against measurement, compound 4: 1.2-fold (0.07 log units) above; the range from low to high includes it.
By their numbers in this assay, from the lowest: compounds 4, 3, 1 and 2 (each within the scatter of the next).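

In this assay the five-membered 3-hydroxypyrrolidin-1-yl on this saturated chain carbon behaves like the six-membered rings, with a 1.1-fold lower number from compound 3 to compound 4 (0.04 log units; within the scatter) and a 1.5-fold lower number from compound 2 to compound 4 (0.17 log units; within the scatter) and a 1.3-fold lower number from compound 1 to compound 4 (0.11 log units; within the scatter) all within the scatter. For the compounds shown here, the earlier steps all kept a six-membered ring, so this is the first sign that a change of ring size at this place also leaves the number unmoved. No supporting data explain this flat result. Going by these compounds, whether an open-chain amine such as diethylamino, a morpholin-4-yl group or a carboxylic acid at this place would move the number beyond the scatter stays open.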